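Compound 3 to compound 4: an aryl exchange

A few compounds are considered here, and "the series" means these few. Any claim that something is new, unique, unknown or untested is made for them only; others in the source may bear on it.

Values so far in a functional assay on MCF7 cells (Homo sapiens) for inhibition, read by MTT assay, with a stated time of 72 h; on this read-out lower numbers stand for stronger inhibition and higher numbers for weaker inhibition
- compound 1 `COc1cc(NC(C)CCCNC(=O)NNC(=O)Nc2ccc(Br)cc2)c2ncccc2c1` gives 100 nM
- compound 2 `COc1cc(NC(C)CCCNC(=O)NNC(=O)Nc2cccc(F)c2)c2ncccc2c1` gives 150 nM
- compound 3 `COc1cc(NC(C)CCCNC(=O)Nc2cccc(C(F)(F)F)c2)c2ncccc2c1` gives 3300 nM

Compound 3 holds the highest number of the three. Its gaps to the others lie beyond the scatter, as a 22-fold higher number from compound 2 to compound 3 (1.34 log units; beyond the scatter) and a 33-fold higher number from compound 1 to compound 3 (1.52 log units; beyond the scatter) show, but those steps remove a carbamoylamino unit, which is not the change at hand. Compound 4 `COc1cc(NC(C)CCCNC(=O)Nc2ccc(Cl)cc2)c2ncccc2c1` carries 4-chlorophenyl in place of 3-(trifluoromethyl)phenyl on an amide-type nitrogen with the rest unchanged. Among the compounds with values here, the closest precedent, one substituted phenyl for another, is a 1.5-fold higher number from compound 1 to compound 2 (0.18 log units; within the scatter) and stays within the scatter, though it is a single step. No step beyond the scatter is therefore expected in this assay and no direction is favoured. The estimated step is a 1.1-fold lower number from compound 3 to compound 4 (0.04 log units; within the scatter) and remains within the scatter. Compound 4 is expected at 3000 nM with an estimated range from 1000 nM to 9000 nM as its bounds.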

Compound 4, half-maximal inhibitory concentration: 12000 nM
The estimate for compound 4 lay 4.0-fold (0.60 log units) below the measured number, outside the stated range (above it).
By their numbers in this assay, from the lowest: compounds 1 and 2 (each within the scatter of the next); then compound 3; then compound 4.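

In this assay, the aryl group on the amide-type nitrogen matters in the compounds without the carbamoylamino unit: the exchange gives a 3.6-fold higher number from compound 3 to compound 4 (0.56 log units; beyond the scatter) and lies beyond the scatter, unlike the earlier aryl exchange with a 1.5-fold higher number from compound 1 to compound 2 (0.18 log units; within the scatter) in the compounds that carry it. The steps that add that unit, an 80-fold higher number from compound 2 to compound 4 (1.90 log units; beyond the scatter) and a 120-fold higher number from compound 1 to compound 4 (2.08 log units; beyond the scatter) when read toward compound 4, remain far larger than the aryl exchange. No measured evidence at hand accounts for the shift.

On these data alone, both the substituent and its ring position change in this step, so neither can be credited alone. 3-Chlorophenyl or 4-(trifluoromethyl)phenyl would separate them, and whether the aryl exchange behaves the same way with the carbamoylamino unit present stays open.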